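The source may hold more compounds than are shown below. What is called first, only, known or untested is meant among the compounds shown, and "the series" means these compounds.

Compounds measured so far:

Compound 1, `C[C@@H]1CCCN1c1c(C#N)c2c(N)nc(Nc3cn(C)nc3Cl)nc2n1C`: 34 nM
Compound 2, `C[C@@H]1CCCN1c1c(C#N)c2c(N)nc(N)nc2n1C`: 248 nM
Compound 3, `C[C@H]1CCCN1c1c(C#N)c2c(N)ncnc2n1C`: 5660 nM

All three were tested in an assay on isolated protein for inhibition of Leucine-rich repeat serine/threonine-protein kinase 2 (Homo sapiens), read by TR-FRET and LanthaScreen, with stated times of 50 min and 30 min, in the presence of a further agent that is not named here; on this read-out higher numbers stand for weaker inhibition and lower numbers for stronger inhibition. Compound 3 stands at the top of the three numbers: its nearest neighbour is compound 2, which gives 248 nM, and the furthest is compound 1, which gives 34 nM. For the measured compounds named here, the only step between compounds differing in one place is a 7.3-fold higher number from compound 1 to compound 2 (0.86 log units; beyond the scatter), a change at a different part of the shared core from the one considered now.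

Compound 4, `C[C@@H]1CCCN1c1c(C#N)c2c(N)ncnc2n1C`, has not yet been measured in this assay. It differs from compound 3 as follows: the two compounds have the same atoms and bonds and differ only in configuration as drawn: 1 of 1 stereo elements differ; a stereocentre at a saturated ring carbon is drawn S in compound 3 and R in compound 4. Going by the values given here, no measured step bears directly on an inversion of this stereocentre, so the size of the step is not anchored by the data. Compounds 1 and 2 carry the configuration drawn for compound 4, and both give lower numbers than compound 3, though each also differs from compound 3 elsewhere. On this basis compound 4 is expected to give a lower number than compound 3, with the step estimated as a 9.4-fold lower number from compound 3 to compound 4 (0.97 log units; beyond the scatter). The estimate for compound 4 is 600 nM, with a range from 100 nM to 3500 nM.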

Compound 4, half-maximal inhibitory concentration: 15 nM
Estimate against measurement, compound 4: 40-fold (1.60 log units) above, and the stated range ends above it.
By their numbers in this assay, from the lowest: compound 4; then compound 1; then compound 2; then compound 3.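

In this assay, for the compounds shown here, inverting the stereocentre at the saturated ring carbon from S to R gives a 380-fold lower number from compound 3 to compound 4 (2.58 log units; beyond the scatter), so this position is strongly sensitive to configuration, which the earlier compounds could not show on their own. The whole of this step can be assigned to the stereocentre, because nothing else separates the two compounds: the fact that compounds 3 and 4 differ only in the configuration as drawn With the R configuration held, the substituent on the aromatic carbon can also be read against plain hydrogen: a 17-fold lower number from compound 2 to compound 4 (1.22 log units; beyond the scatter) for hydrogen in place of amino, and a 2.3-fold lower number from compound 1 to compound 4 (0.36 log units; beyond the scatter) for hydrogen in place of (3-chloro-1-methyl-1H-pyrazol-4-yl)amino, so neither group improves on hydrogen among these three compounds.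

It remains open whether the inversion has a similar effect when that aromatic carbon carries amino or (3-chloro-1-methyl-1H-pyrazol-4-yl)amino, as the only pair shown that differs at the stereocentre has hydrogen there. From the compounds shown here alone, it is also open how a methyl or methoxy group on that carbon would compare with hydrogen, and whether an ethyl group in place of the methyl at the stereocentre would keep the same preference in configuration.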